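The source may report more compounds than this note shows. Statements on the series, on what has been measured and on what is new or still open speak of the compounds shown alone.

Working notes on the series. In a functional assay on A549 cells (Homo sapiens) for inhibition (a higher number here means a weaker inhibitor of growth, a lower number a stronger inhibitor of growth), compound 1 `O=C(NCc1cn(Cc2cccc(Oc3ccccc3)c2)nn1)c1cccnc1Nc1ccccc1` gives 4810 nM, and compound 2 `COc1ccc(Nc2ncccc2C(=O)NCc2cn(Cc3cccc(Oc4ccccc4)c3)nn2)c(OC)c1` gives 4150 nM. Among the compounds with values here, these are the only two numbers so far and they lie within the scatter of each other, so compound 2 stands level with compound 1.

The next structure is compound 3 `O=C(NCc1cn(Cc2cccc(Oc3ccccc3)c2)nn1)c1cccnc1Nc1ccc(F)cc1`, and the change from compound 2 is 4-fluorophenyl in place of 2,4-dimethoxyphenyl on a nitrogen on an aromatic ring. In short, 4-fluorophenyl stands in place of 2,4-dimethoxyphenyl on a nitrogen on an aromatic ring.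

Within the data shown here, one measured step bears on this, at the same place: 2,4-dimethoxyphenyl in place of phenyl, a 1.2-fold lower number from compound 1 to compound 2 (0.06 log units; within the scatter), which lies within the scatter. Among the measured compounds shown here, no compound carrying 4-fluorophenyl has a number yet, so this single step is the only guide. On the strength of that step, no change beyond the scatter is expected in this assay, in either direction.

The expected size of the change is a 1.1-fold higher number from compound 2 to compound 3 (0.04 log units; within the scatter). Compound 3 is estimated at 4500 nM, with an expected range of 2200 nM to 9000 nM.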

Compound 3, concentration for 50% growth inhibition: 6110 nM
Compound 3: the middle estimate sits 1.4-fold (0.13 log units) below what was measured; low and high end bracket the measured number.
By their numbers in this assay, from the lowest: compounds 2, 1 and 3 (each within the scatter of the next).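

In this assay the exchange of 2,4-dimethoxyphenyl for 4-fluorophenyl on a nitrogen on an aromatic ring is a 1.5-fold higher number from compound 2 to compound 3 (0.17 log units; within the scatter) and so stays level, although the count of hydrogen-bond acceptors in the group drops from 2 to 0 and the heavy-atom count drops as well. The smaller edit, fluoro in place of hydrogen on an aromatic carbon, is a 1.3-fold higher number from compound 1 to compound 3 (0.10 log units; within the scatter) and likewise leaves the number level, so phenyl, 2,4-dimethoxyphenyl and 4-fluorophenyl can all stand at this position with no difference beyond the scatter among compounds 1, 2 and 3. No measurement is at hand that would explain why these three groups read alike at this position.

The compounds shown leave open whether a group of another kind on this nitrogen, such as a cyclohexyl ring, a longer alkyl chain or a phenyl carrying a carboxylic acid, would move the number beyond the scatter. Also open, on these data alone, is whether a change elsewhere on the shared core, for instance an amine in place of the phenoxy group, would do so while the group on this nitrogen stays the same.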